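This account rests on a few compounds, and the source may have more. Where it says the series, first, only, none or still open, it means among the compounds named here.

Measured in a toxicity assay on HEK293 cells (Homo sapiens) for inhibition, read by resazurin assay, with a stated time of 24 h; a lower number here means that less compound is tolerated, a higher number that more compound is tolerated:
- Compound 1 `CN(C)C(=O)c1ncc([N+](=O)[O-])[nH]1`: > 100000 nM, a limit of the assay.
- Compound 2 `NC(=O)c1ncc([N+](=O)[O-])[nH]1`: > 100000 nM, a limit of the assay.
- Compound 3 `CNC(=O)c1nc([N+](=O)[O-])cn1Cc1ccc(OC(F)(F)F)cc1`: > 100000 nM, a limit of the assay.

Compound 3 therefore gives no number, only a limit, and the series sits there throughout: the limit of > 100000 nM in this assay, at which 3 of the 3 values shown sit. Compound 4 `O=C(NO)c1nc([N+](=O)[O-])cn1Cc1ccc(OC(F)(F)F)cc1` carries hydroxy in place of methyl on an amide-type nitrogen. The nearest measured change is a step that the two limits leave unreadable from compound 1 to compound 2, which gives no size to carry over. No step beyond the scatter is expected in this assay, though a drop cannot be excluded with only limits to go on. The expected step is a number no higher from compound 3 to compound 4 (the limit leaves the size open). For compound 4 the estimate is 100000 nM, with an expected range of 30000 nM to 200000 nM.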

Compound 4, half-maximal cytotoxic concentration: 36000 nM
Estimate against measurement, compound 4: 2.8-fold (0.44 log units) above; the range from low to high includes it.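

Among these compounds, on the amide-type nitrogen, hydroxy in place of methyl gives the only number in this assay that is not a limit, with an at least 2.7-fold lower number from compound 3 to compound 4 (0.44 log units; beyond the scatter). As far as these compounds go, this place on the shared core can therefore lower the tolerated concentration, and the true size of the step stays open. The other compounds give no such reading: the limit of > 100000 nM in this assay, at which 3 of the 4 values shown sit.

From the compounds shown here alone, it remains open whether methoxy or an amino group on that nitrogen would lower the number as well. Going by these compounds, it also remains open whether hydroxy has the same effect on other compounds.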